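Tert-butyl to trifluoromethoxy: an untested step in cell toxicity

A few compounds are considered here, and "the series" means these few. Any claim that something is new, unique, unknown or untested is made for them only; others in the source may bear on it.

Compound 1 `CCc1ccc2[nH]c(=O)c(CN(Cc3ccc(C(C)(C)C)cc3)[C@@H](C)c3ccc(OC)cc3)cc2c1`: > 5000 nM, a limit of the assay.
Compound 2 `COc1ccc(CN(Cc2ccc(C(C)(C)C)cc2)Cc2cc3ccccc3[nH]c2=O)cc1`: 1800 nM.
Compound 3 `COc1ccc([C@H](C)N(Cc2ccc(C(C)(C)C)cc2)Cc2cc3ccccc3[nH]c2=O)cc1`: 1800 nM.

Going by the values given here, in a toxicity assay on MDCK cells (Canis lupus familiaris) for cytotoxicity, read by crystal violet staining, with a stated time of 48 h (on this read-out lower numbers stand for higher toxicity in this test and higher numbers for lower toxicity in this test), compound 3 stands level with compound 2, and the one remaining value is a limit. The change to compound 4 `COc1ccc([C@H](C)N(Cc2ccc(OC(F)(F)F)cc2)Cc2cc3ccccc3[nH]c2=O)cc1` is trifluoromethoxy in place of tert-butyl on an aromatic carbon. Neither measured step touches that part of the molecule: an at least 2.7-fold lower number from compound 1 to compound 3 (0.44 log units; beyond the scatter) concerns a group on the shared core, and no change at the digits printed from compound 2 to compound 3 (within the scatter) concerns the chain carbon next to the amine nitrogen. Among the compounds with values here, no measured step therefore bears on the swap itself, and a step within the scatter is expected, a 1.3-fold higher number from compound 3 to compound 4 (0.12 log units; within the scatter), in this assay. Compound 4 is estimated at 2400 nM, with a range from 900 nM to 6500 nM.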

Compound 4, half-maximal cytotoxic concentration: > 10000 nM
Compound 4 gave a limit, no number; the forecaster's own chance of this, stated with the estimate: 25%; at least 4.1-fold (0.61 log units) between middle value and limit.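

Trifluoromethoxy in place of tert-butyl gives an at least 5.5-fold higher number from compound 3 to compound 4 (0.74 log units; beyond the scatter) in this assay, so this aromatic position, which no earlier step touched, does register in this read-out. Compound 4 carries no number, only a limit of the assay: the limit of > 10000 nM in this assay, at which 1 of the 4 values shown sits. The size of the step is therefore a bound and not a measure.

The compounds shown leave open whether the same swap would carry over to the ethyl-bearing core of compound 1 or to compound 2, which lacks the chain methyl. They also leave open how a nitrile or a primary amine would read at this place.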